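The source may report more compounds than this note shows. Statements on the series, on what has been measured and on what is new or still open speak of the compounds shown alone.

Compound 1 `COc1cc(/C=N/Nc2nc3ccccc3s2)cc(OC)c1O` gives, in a physicochemical assay on cells (Homo sapiens), with a stated time of 18 h, tested at 10 uM (a higher number here means a weaker effect of the compound at the concentration tested, a lower number a stronger effect), a reading of 3%, and compound 2 `COc1cc(/C=N/N(C)c2nc3ccccc3s2)cc(OC)c1O` gives 3%, so compound 1 stands level with compound 2. Among the compounds with values here, the only measured step, no change at the digits printed from compound 1 to compound 2 (within the scatter), stayed within the scatter. Compound 3 `COc1cc(/C=N/Nc2nc3ccccc3s2)cc(O)c1O` differs from compound 1 by hydrogen in place of methyl on an oxygen on an aromatic ring. That change sits at a different place from the measured step, so that step bears on it only loosely. Because the step of no change at the digits printed from compound 1 to compound 2 (within the scatter) left the reading unchanged, the expected step is no change at the digits printed from compound 1 to compound 3 (within the scatter), nothing beyond the scatter. For compound 3 the estimate is 3%, within a range from 0% to 15%.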

Compound 3, a percentage reported as activity, at one concentration (the size of the read-out at that concentration, not a potency): 7%
Compound 3: middle estimate off by 4 percentage points, on the low side, within the range that was stated.
By their numbers in this assay, from the lowest: compounds 1, 2 and 3 (each within the scatter of the next).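

In this assay, within the data shown here, the change from methoxy to hydroxy on the aromatic ring gives a number 4 percentage points higher from compound 1 to compound 3 (within the scatter) and so shows, for the first time, that the methyl on this oxygen can go without the reading leaving the scatter. The earlier pair showed this only for the methyl on the nitrogen. No measured evidence accounts for this result. The compounds shown leave open whether a longer chain on this oxygen, such as ethyl or propyl, or an amine in place of the methoxy, would move the reading beyond the scatter.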